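Morpholine in place of ethylpiperazine on the sulfonyl group

The source may hold more compounds than are shown below. What is called first, only, known or untested is meant among the compounds shown, and "the series" means these compounds.

Compound 1 `CCN1CCN(S(=O)(=O)CCCN2CCC(CNC(=O)c3cccc4c3OCCO4)CC2)CC1` gives 0.0501 nM in an assay on isolated protein for inhibition of 5-hydroxytryptamine receptor 4 (Homo sapiens); a lower number here means a stronger inhibitor, a higher number a weaker inhibitor. Among the three compounds measured it stands second highest: compound 2 `CC(C)N1CCN(S(=O)(=O)CCCN2CCC(CNC(=O)c3cccc4c3OCCO4)CC2)CC1` gives 0.0316 nM, a difference within the scatter, while compound 3 `CC1(C)CCN(S(=O)(=O)CCCN2CCC(CNC(=O)c3cccc4c3OCCO4)CC2)CC1` gives 0.126 nM. The step to compound 4 `O=C(NCC1CCN(CCCS(=O)(=O)N2CCOCC2)CC1)c1cccc2c1OCCO2` is morpholin-4-yl in place of 4-ethylpiperazin-1-yl on a sulfonyl sulfur. The closest precedents are a 2.5-fold higher number from compound 1 to compound 3 (0.40 log units; beyond the scatter) and a 4.0-fold higher number from compound 2 to compound 3 (0.60 log units; beyond the scatter), where the ring bound to the sulfonyl sulfur likewise lost its second nitrogen and its alkyl substituent, and the number rose modestly. Compound 4 is therefore expected to show a modest rise, about a 2.4-fold higher number from compound 1 to compound 4 (0.38 log units; beyond the scatter). The estimate for compound 4 is 0.12 nM, with a range from 0.04 nM to 0.4 nM.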

Compound 4, inhibition constant: 0.398 nM
Compound 4: the middle estimate sits 3.3-fold (0.52 log units) below what was measured, within the range that was stated.
By their numbers in this assay, from the lowest: compounds 2 and 1 (each within the scatter of the next); then compound 3; then compound 4.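

At the sulfonyl sulfur, morpholin-4-yl carries the highest number of the four compounds in this assay and shows a 7.9-fold higher number from compound 1 to compound 4 (0.90 log units; beyond the scatter) and a 13-fold higher number from compound 2 to compound 4 (1.10 log units; beyond the scatter) against the alkylated piperazines. It also shows a 3.2-fold higher number from compound 3 to compound 4 (0.50 log units; beyond the scatter), so the two rings without a second nitrogen differ beyond the scatter, and losing that nitrogen does not alone fix the number. Nothing available explains this gap. The compounds shown leave open where a piperazine with a free ring nitrogen or a thiomorpholine would stand at this sulfonyl sulfur.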